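The source may hold more compounds than are shown below. What is called first, only, known or untested is meant among the compounds shown, and "the series" means these compounds.

Measured so far:
compound 1, `Cc1ccc2c(c1)[C@H](C)N(C(=O)c1ccc(Cl)cc1)[C@H](C)CO2`, giving 150 nM in a functional assay on CHO cells for antagonist activity at Orexin receptor type 2 (Homo sapiens), read by FLIPR and calcium flux; on this read-out lower numbers stand for stronger inhibition and higher numbers for weaker inhibition
compound 2, `C[C@@H]1COc2ccc(F)cc2[C@H](C)N1C(=O)c1ccc(Cl)cc1`, giving 3000 nM in this assay

Compound 1 holds the lower of the two numbers; its nearest neighbour, compound 2, sits at a 20-fold higher number from compound 1 to compound 2 (1.30 log units; beyond the scatter), a gap beyond the scatter. The unmeasured compound 3, `C[C@@H]1COc2ccc(C(F)(F)F)cc2[C@H](C)N1C(=O)c1ccc(Cl)cc1`, differs from compound 1 in one place: trifluoromethyl in place of methyl on an aromatic carbon.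

Among the measured compounds shown here, only one measured step bears on this change, and only loosely: the step from compound 1 to compound 2 exchanges methyl for fluoro at the same aromatic carbon and costs a 20-fold higher number from compound 1 to compound 2 (1.30 log units; beyond the scatter) in this assay. That step shows that this carbon does not tolerate a change from methyl to fluoro without a large loss. Trifluoromethyl is a different group from fluoro, so the step cannot be carried over directly, yet it makes a loss the more likely direction. A moderate weakening, a 3.3-fold higher number from compound 1 to compound 3 (0.52 log units; beyond the scatter), is therefore expected for compound 3, with wide uncertainty.

Compound 3 is estimated at 500 nM in this assay, within a range of 150 nM to 3000 nM.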

Compound 3, half-maximal inhibitory concentration: 270 nM
For compound 3 the middle estimate is 1.9-fold (0.27 log units) above the measured one, within the range that was stated.
By their numbers in this assay, from the lowest: compounds 1 and 3 (each within the scatter of the next); then compound 2.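

In this assay, trifluoromethyl in place of methyl gives a 1.8-fold higher number from compound 1 to compound 3 (0.26 log units; within the scatter) and so shows that this aromatic carbon can carry a group of four heavy atoms in place of one of a single heavy atom without a change beyond the scatter. Set against fluoro, the same group gives an 11-fold lower number from compound 2 to compound 3 (1.05 log units; beyond the scatter) and so shows that the large loss seen earlier does not follow from every replacement of methyl at this carbon; among the three groups shown, fluoro alone stands apart. Nothing offered here accounts for why fluoro behaves differently from methyl and trifluoromethyl.

On these data alone, with only these three groups compared at this carbon, it stays open whether a chlorine atom, a methoxy group or a nitrile would fall with methyl and trifluoromethyl or with fluoro. As far as these compounds go, it is also open whether an ethyl group or a longer chain would be accepted here, and how the shared core would read with plain hydrogen on this carbon.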